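Two aryl ureas and their ethyl homologues

A few compounds are considered here, and "the series" means these few. Any claim that something is new, unique, unknown or untested is made for them only; others in the source may bear on it.

Compound 1 `Cc1ccccc1NC(=O)N[C@H](C)c1ccccc1` and compound 3 `CCc1ccccc1NC(=O)N[C@H](C)c1ccccc1` share one core; compound 2 `Cc1ccc(NC(=O)N[C@H](C)c2ccccc2)cc1` and the as yet unmeasured compound 4 `CCc1ccc(NC(=O)N[C@H](C)c2ccccc2)cc1` share another. The difference between the two cores is not broken down here. In an ADME assay on the whole organism with Oryza sativa as the target, tested at 1 uM (a lower number here means a stronger effect, a higher number a weaker effect of the compound at the concentration tested), compound 1 gives 100% and compound 3 gives 100%, so that no change at the digits printed from compound 1 to compound 3 (within the scatter); the change between them is methyl in place of hydrogen on a saturated chain carbon bound to an aromatic carbon. Compound 2 gives 98%, a number that lies within the usual scatter of the values of compound 1 and compound 3.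

Compound 4 is the corresponding homologue of compound 2: the change is methyl in place of hydrogen on a saturated chain carbon bound to an aromatic carbon, the same change as from compound 1 to compound 3, at the same kind of place. Going by the values given here, the only measured instance of this change, no change at the digits printed from compound 1 to compound 3 (within the scatter), left the read-out where it was, and all three measured values sit at or near the top of the scale. For compound 4 the expected step is therefore no change at the digits printed from compound 2 to compound 4 (within the scatter), resting on no change at the digits printed from compound 1 to compound 3 (within the scatter) and on the value of compound 2, 98%. Compound 4 is estimated at 98%, with a range from 88% to 100%.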

Compound 4, a percentage reported as activity, at one concentration (the size of the read-out at that concentration, not a potency): 47%
Estimate against measurement, compound 4: 51 percentage points above, outside the stated range (below it).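

Methyl in place of hydrogen on a saturated chain carbon bound to an aromatic carbon gives, in this assay, a number 51 percentage points lower from compound 2 to compound 4 (beyond the scatter), so the result of this change on the core of compound 1 does not carry over to the core of compound 2. The two cores part on this change: the same change on two cores in this assay, no change at the digits printed (within the scatter) from compound 1 to compound 3 and a number 51 percentage points lower (beyond the scatter) from compound 2 to compound 4, 51 percentage points apart, beyond the scatter of two such steps

This is a single pair of steps, and it does not show what in the two cores sets them apart, nor how any other change would carry from one core to the other.

Open, on these data alone, is whether a longer chain such as propyl, in place of the ethyl group of compound 4, would keep, deepen or lose the lower read-out. Equally open, as far as these compounds go, is whether the same longer chain on the core of compound 1 would leave the read-out where compound 3 has it, at 100%.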